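Replacing a Methylpyridine Arm with a Triazole

This account rests on a few compounds, and the source may have more. Where it says the series, first, only, none or still open, it means among the compounds named here.

Compound 2 `CCC(C)(C)Cc1c[nH]c(CCc2ccc(-c3cccc(C)n3)cc2)n1` gives 102 nM in a functional assay on HEK293 cells for agonist activity at Bombesin receptor subtype-3 (Homo sapiens), read by luminescence and calcium flux, with a stated time of 10 min; a higher number here means that more compound is needed for the effect, a lower number that less compound is needed. Among the two numbers measured it stands nearest compound 1 `CCC(C)(C)Cc1c[nH]c(CCc2ccc(-c3cccnc3C(=O)O)cc2)n1`, which gives 95 nM, and the step of a 1.1-fold higher number from compound 1 to compound 2 (0.03 log units; within the scatter) lies within the scatter, so neither compound stands apart. Compound 3 `CCC(C)(C)Cc1c[nH]c(CCc2ccc(-n3cncn3)cc2)n1` differs from compound 2 by 1H-1,2,4-triazol-1-yl in place of 6-methylpyridin-2-yl on an aromatic carbon. For the measured compounds named here, the one measured step, a 1.1-fold higher number from compound 1 to compound 2 (0.03 log units; within the scatter), exchanged one six-membered ring for another and changed nothing beyond the scatter, so there is no direct guide for moving to a five-membered ring with fewer heavy atoms. A step of a 2.0-fold higher number from compound 2 to compound 3 (0.29 log units; within the scatter) is expected, a modest rise with wide uncertainty. Compound 3 is estimated at 200 nM, with a range from 60 nM to 700 nM.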

Compound 3, half-maximal effective concentration: 89 nM
Compound 3: the middle estimate sits 2.2-fold (0.35 log units) above what was measured; measured number inside the range.
By their numbers in this assay, from the lowest: compounds 3, 1 and 2 (each within the scatter of the next).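

At this position, on an aromatic carbon para to a large group, the five-membered 1H-1,2,4-triazol-1-yl ring takes the place of the six-membered 6-methylpyridin-2-yl ring with no change beyond the scatter in this assay (a 1.1-fold lower number from compound 2 to compound 3 (0.06 log units; within the scatter)). The same holds when it replaces 2-carboxypyridin-3-yl (a 1.1-fold lower number from compound 1 to compound 3 (0.03 log units; within the scatter)), so among these three compounds, ring size does not move the number beyond the scatter. No measurement at hand explains this tolerance.

The compounds shown all carry an aromatic ring here, so it remains open whether an amine or a longer alkyl chain in its place would keep the number in this range.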